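A Pyrrolidine in Place of the Aminopropyl Chain

The compounds below may be only part of what the source reports. "The series", "measured", "known", "first", "only" and "open" are said of these compounds alone.

compound 1 `COc1cccc(-c2c(C)n(Cc3c(F)cccc3F)c(=O)n([C@H](C)CNCc3ccccc3)c2=O)c1`: 75 nM
compound 2 `COc1cccc(-c2c(C)n(Cc3c(F)cccc3F)c(=O)n([C@H](C)CNCC(C)C)c2=O)c1`: 190 nM
compound 3 `COc1cccc(-c2c(C)n(Cc3c(F)cccc3F)c(=O)n([C@H](C)CNCc3ccccc3F)c2=O)c1`: 90 nM

In an assay on HEK293 cells for binding affinity to Gonadotropin-releasing hormone receptor (Homo sapiens) (a lower number here means a stronger inhibitor, a higher number a weaker inhibitor), compound 3 gives 90 nM, the second highest of the three numbers. The step of a 1.2-fold higher number from compound 1 to compound 3 (0.08 log units; within the scatter) lies within the scatter, whereas a 2.1-fold lower number from compound 2 to compound 3 (0.32 log units; beyond the scatter) lies beyond it. Compound 4 `COc1cccc(-c2c(C)n(Cc3c(F)cccc3F)c(=O)n(C3CCNC3)c2=O)c1` differs from compound 3 by pyrrolidin-3-yl in place of 1-(((2-fluorobenzyl)amino)methyl)ethyl on an aromatic nitrogen. Among the measured compounds shown here, the measured steps of a 2.5-fold higher number from compound 1 to compound 2 (0.40 log units; beyond the scatter) and a 2.1-fold lower number from compound 2 to compound 3 (0.32 log units; beyond the scatter) were both modest and altered only the group on the amine nitrogen; no measured step removes the chain or introduces a ring, so they bear on this change only loosely. A loss of affinity is expected, of about a 4.4-fold higher number from compound 3 to compound 4 (0.65 log units; beyond the scatter), with wide uncertainty. Compound 4 is therefore estimated at 400 nM, within a range from 80 nM to 2000 nM.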

Compound 4, inhibition constant: 15000 nM
For compound 4 the middle estimate is 38-fold (1.57 log units) below the measured one; the whole stated range lies below it.
By their numbers in this assay, from the lowest: compounds 1 and 3 (each within the scatter of the next); then compound 2; then compound 4.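

In this assay, pyrrolidin-3-yl on the aromatic nitrogen gives a large loss against the benzylamino chain (a 200-fold higher number from compound 1 to compound 4 (2.30 log units; beyond the scatter)), the isobutylamino chain (a 79-fold higher number from compound 2 to compound 4 (1.90 log units; beyond the scatter)) and the 2-fluorobenzylamino chain (a 170-fold higher number from compound 3 to compound 4 (2.22 log units; beyond the scatter)). Among the compounds shown here, each loss far exceeds the steps among the earlier compounds, which changed only the group on the amine nitrogen, so replacing the whole chain at this position weighs much more than exchanging that group. Nothing available accounts for the size of this loss.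

Compound 4 both closes a ring and drops the group on the amine nitrogen, so the two changes cannot be told apart. A pyrrolidine carrying a benzyl group on its nitrogen would separate them.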